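Chloro to methyl on the shared core: an expectation

This account rests on a few compounds, and the source may have more. Where it says the series, first, only, none or still open, it means among the compounds named here.

Measured so far:
- compound 1, `Clc1ccc(-c2cc(-c3ccsc3)nc(-c3ccccc3Cl)c2)o1`: 4570 nM
- compound 2, `Clc1ccc(-c2cc(-c3cccnc3)nc(-c3cccs3)c2)o1`: 1240 nM

Of the compounds shown here, two have been measured in a functional assay on HCT-15 cells (Homo sapiens) for cytotoxicity, in the presence of a further agent that is not named here; a lower number here means a stronger inhibitor, a higher number a weaker inhibitor. Compound 1 gives 4570 nM, the highest of the two numbers, and so the weaker inhibitor of the pair. Compound 2 gives 1240 nM, a lower number that lies beyond the scatter. The two differ in more than one place, so nothing can be read from them about any single change.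

Compound 3, `Cc1ccccc1-c1cc(-c2ccc(Cl)o2)cc(-c2ccsc2)n1`, has not yet been measured. It differs from compound 1 in one place: methyl in place of chloro on an aromatic carbon. Read one bond further out, 2-chlorophenyl becomes 2-methylphenyl. Going by the values given here, with no measured pair to lean on, the step of a 1.1-fold lower number from compound 1 to compound 3 (0.06 log units; within the scatter) is expected to be small, in no fixed direction and likely within the scatter. Compound 3 is therefore estimated at 4000 nM, with a range from 1500 nM to 12000 nM.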

Compound 3, half-maximal inhibitory concentration: 4630 nM
Beside the measured number, compound 3's estimate is 1.2-fold (0.06 log units) below it, within the range that was stated.
By their numbers in this assay, from the lowest: compound 2; then compounds 1 and 3 (each within the scatter of the next).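

In this assay, replacing the chloro of the 2-chlorophenyl group with methyl, to give 2-methylphenyl, is a 1.0-fold higher number from compound 1 to compound 3 (0.01 log units; within the scatter), so the two compounds cannot be told apart. Going by these compounds alone, this is the first measured pair that differs in one place, and it shows that on this aromatic carbon, ortho to a large group, chloro and methyl are interchangeable as far as this read-out can tell. No measurement at hand offers an explanation for this match.

Still open, from the compounds shown here alone, is how the number would respond to a different group at this position, such as an amine, a carboxylic acid or a longer chain. Also open, going by these compounds, is whether the same swap would read alike with other groups elsewhere on the shared core, and compound 2 cannot help here, since it differs from compound 1 in more than one place.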